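Compound 3: from 4-fluorobenzyl to 3-methylbenzyl

The source may hold more compounds than are shown below. What is called first, only, known or untested is meant among the compounds shown, and "the series" means these compounds.

Measured so far in a functional assay on HCT-116 cells (Homo sapiens) for inhibition, read by MTT assay, with a stated time of 72 h (on this read-out lower numbers stand for stronger inhibition and higher numbers for weaker inhibition), are two compounds:
- compound 1 `Cc1ccc(CN2CCc3ncn(COCc4ccccc4)c3/C(=C/c3ccccc3)C2=O)cc1` gives 7940 nM
- compound 2 `O=C1/C(=C\c2ccccc2)c2c(ncn2COCc2ccccc2)CCN1Cc1ccc(F)cc1` gives 11200 nM

Going by the values given here, on these numbers, compound 2 cannot be told apart from compound 1, the only other compound measured. The gap between them is no larger than repeat measurements of a single compound would normally show.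

The next compound is compound 3 `Cc1cccc(CN2CCc3ncn(COCc4ccccc4)c3/C(=C/c3ccccc3)C2=O)c1` and it differs from compound 2 as follows: 3-methylphenyl in place of 4-fluorophenyl on a saturated chain carbon bound to an amide-type nitrogen in a ring with the shared core unchanged. The same difference, cut one bond further out, reads 4-fluorobenzyl to 3-methylbenzyl.

Among the compounds with values here, only one measured step bears on this change, a 1.4-fold higher number from compound 1 to compound 2 (0.15 log units; within the scatter) and it came from fluoro in place of methyl on an aromatic carbon. Within the data shown here, no measured compound carries a 3-methylphenyl group, so the evidence is indirect.

No step beyond the scatter is therefore expected in this assay and the estimated move is a 1.3-fold lower number from compound 2 to compound 3 (0.12 log units; within the scatter) in this case. Compound 3 is estimated at 8500 nM with an expected range from 4500 nM to 16000 nM as the likely span.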

Compound 3, half-maximal inhibitory concentration: 3800 nM
Beside the measured number, compound 3's estimate is 2.2-fold (0.35 log units) above it, and the stated range ends above it.
By their numbers in this assay, from the lowest: compound 3; then compounds 1 and 2 (each within the scatter of the next).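

Going by these compounds alone, until now, the aromatic group at this place on the shared core looked freely exchangeable in this assay, as the one earlier step (a 1.4-fold higher number from compound 1 to compound 2 (0.15 log units; within the scatter)) stayed within the scatter. Compound 3 changes that picture: 3-methylphenyl in place of 4-fluorophenyl gives a modest but real drop (a 2.9-fold lower number from compound 2 to compound 3 (0.47 log units; beyond the scatter)), and 3-methylphenyl in place of 4-methylphenyl gives another (a 2.1-fold lower number from compound 1 to compound 3 (0.32 log units; beyond the scatter)), so among these three compounds the same methyl group gives a different number depending on where it sits on the ring, and compound 3 is the most potent of the three. Nothing shown here explains why the 3-methylphenyl group goes with the lower number.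

From the compounds shown here alone, it remains open whether the drop belongs to the methyl group itself or would also appear with a fluoro, chloro or methoxy group at that same ring position of the benzyl group. Also open, going by these compounds, is how an unsubstituted phenyl ring, a pyridine ring or a longer chain between the ring and the amide-type nitrogen would compare with the 3-methylphenyl group, and a gain this modest does not yet show how far this position can be pushed.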